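The source may hold more compounds than are shown below. What is called first, only, known or untested is meant among the compounds shown, and "the series" means these compounds.

Two ester compounds on the same core have been measured in an ADME assay (liver) for pharmacokinetics, with Liver microsome (Homo sapiens) as the target, using microsomes; on this read-out higher numbers stand for a longer-lived compound and lower numbers for a shorter-lived compound. Compound 1 `CCOc1cc(NC(=O)C2(NC(=O)c3ccc4c(C5CCCC5)c(-c5ncc(Cl)cn5)n(C)c4c3)CCC2)ccc1/C=C/C(=O)OCOP(=O)(O)O` gives 0.167 h in this assay, and compound 2 `CCOc1cc(NC(=O)C2(NC(=O)c3ccc4c(C5CCCC5)c(-c5ncc(Cl)cn5)n(C)c4c3)CCC2)ccc1/C=C/C(=O)OCCOCCOC` gives 0.85 h. Compound 2 thus stands highest of the two numbers, its nearest neighbour being compound 1, reached by the step of a 5.1-fold higher number from compound 1 to compound 2 (0.71 log units; beyond the scatter). The next compound, compound 3 `CCOc1cc(NC(=O)C2(NC(=O)c3ccc4c(C5CCCC5)c(-c5ncc(Cl)cn5)n(C)c4c3)CCC2)ccc1/C=C/C(=O)OCC(=O)OC`, differs from compound 2 in one place: methoxycarbonyl in place of (2-methoxyethoxy)methyl on a saturated chain carbon bound to an oxygen next to a carbonyl group. Within the data shown here, no measured step covers this exchange directly; the only step known, from compound 1 to compound 2, swapped a different group at the same place and was modest in size. Among the measured compounds shown here, because compound 2 gives 0.85 h and the one known step at this place moved the number by a modest amount, a step of modest size, downward, is expected from compound 2 to compound 3 in this assay, a 1.7-fold lower number from compound 2 to compound 3 (0.23 log units; within the scatter). Compound 3 is therefore estimated at 0.5 h, within a range from 0.15 h to 1.7 h.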

Compound 3, half-life: 2.1 h
Estimate against measurement, compound 3: 4.2-fold (0.62 log units) below; the whole stated range lies below it.
By their numbers in this assay, from the lowest: compound 1; then compound 2; then compound 3.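

In this assay this position proved able to carry the number further up than compound 2 had shown: methoxycarbonyl in place of (2-methoxyethoxy)methyl gave a 2.5-fold higher number from compound 2 to compound 3 (0.39 log units; beyond the scatter), a step beyond the scatter. The two groups count the same hydrogen-bond acceptors and neither has a net charge, so these counts do not separate them, while the shorter group with its double bond gave the higher number. With a 13-fold higher number from compound 1 to compound 3 (1.10 log units; beyond the scatter), the position now shows a large span across the three groups on the saturated chain carbon, although nothing available explains this order.

Compound 2 and compound 3 differ in both chain size and the presence of the carbonyl, so the compounds shown cannot say which of the two goes with the higher number. Going by these compounds, it also remains open how a carboxylic acid, an ethoxycarbonyl group or a simple methoxymethyl group would stand at this place, the last of these being the comparison that would keep the ether form while shortening the chain.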